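Swapping a chlorophenyl for a fluorophenyl on the shared core

A few compounds are considered here, and "the series" means these few. Any claim that something is new, unique, unknown or untested is made for them only; others in the source may bear on it.

Compound 3 `O=S(=O)(Nc1ccc(F)c(C#Cc2cnc3[nH]nc(-c4cccc(Cl)c4)c3c2)c1F)c1cccnc1` sits at the edge of what the numbers show. In a functional assay on HCT-116 cells (Homo sapiens) for antiproliferative activity, read by MTT assay, with a stated time of 68 h (on this read-out higher numbers stand for weaker inhibition and lower numbers for stronger inhibition), compound 3 gives > 10000 nM, which is a limit of the assay rather than a number. Compound 1 `CCOc1n[nH]c2ncc(C#Cc3c(F)ccc(NS(=O)(=O)c4cccnc4)c3F)cc12` gives 10000 nM in this assay. Compound 2 `O=S(=O)(Nc1ccc(F)c(C#Cc2cnc3[nH]nc(-c4ccccc4Cl)c3c2)c1F)c1cccnc1` gives > 10000 nM in this assay, again a limit. The steps of a number no lower from compound 1 to compound 2 (the limit leaves the size open), a number no lower from compound 1 to compound 3 (the limit leaves the size open) and a step that the two limits leave unreadable from compound 2 to compound 3 therefore have no readable size; the limit of > 10000 nM in this assay, at which 2 of the 3 values shown sit, marks where two of the three values sit.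

Compound 4 `O=S(=O)(Nc1ccc(F)c(C#Cc2cnc3[nH]nc(-c4ccc(F)cc4)c3c2)c1F)c1cccnc1` differs from compound 3 by 4-fluorophenyl in place of 3-chlorophenyl on an aromatic carbon. Going by the values given here, no measured step covers this swap; the measured steps only put aryl groups in place of ethoxy. The step that the limit leaves unreadable from compound 3 to compound 4 is expected to be none beyond the scatter. Compound 4 is expected to give 12000 nM in this assay, between 4000 nM and 35000 nM, quite possibly again as a limit.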

Compound 4, half-maximal inhibitory concentration: > 10000 nM
Compound 4: no number, only a limit (the forecaster's own chance of this, stated with the estimate: 60%); the middle value does not contradict the limit.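

With 4-fluorophenyl on this aromatic carbon, compound 4 gives > 10000 nM in this assay, again a limit of the assay and not a number. Putting this group in place of ethoxy gives a number no lower from compound 1 to compound 4 (the limit leaves the size open), and the steps among the three aryl compounds cannot be read. A fluorinated phenyl thus yields no readable number here, just as the two chlorophenyl groups yielded none: the limit of > 10000 nM in this assay, at which 3 of the 4 values shown sit.

On these data alone, whether the 4-fluorophenyl differs at all from the chlorophenyl groups stays open. So does whether an amine or a longer alkoxy chain at this position would give a readable number.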